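The compounds below may be only part of what the source reports. "The series", "measured", "known", "first", "only" and "open" are said of these compounds alone.

Of the compounds shown here, three have been measured in an ADME assay on microsomes from liver (Rattus norvegicus) for metabolic stability, read by LC-MS, using NADPH, with a stated time of 30 min, tested at 1 uM; on this read-out lower numbers stand for slow clearance and higher numbers for fast clearance. Compound 1 `CC(C)c1noc(N2CCC(Oc3cc(N4CCc5cc(N6CCCCC6=O)ccc54)ncn3)CC2)n1` gives 13 mL.min-1.g-1, compound 2 `CCc1cnc(N2CCC(C(C)COC(=O)N3CCc4cc(S(C)(=O)=O)cc(F)c43)CC2)nc1` gives 365 mL.min-1.g-1, and compound 3 `CC(=O)N(C)c1ccc2c(c1)CCN2c1cc(OC2CCN(c3nc(C(C)C)no3)CC2)ncn1` gives 17 mL.min-1.g-1. Compound 3 thus stands second highest of the three: compound 1 is nearest, with the step of a 1.3-fold higher number from compound 1 to compound 3 (0.12 log units; within the scatter) lying within the scatter, while compound 2, built on a different core, stands furthest away and well beyond it.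

The unmeasured compound 4 `CC(C)c1noc(N2CCC(Oc3cc(N4CCc5cc(N6CCC(O)CC6=O)ccc54)ncn3)CC2)n1` differs from compound 3 in one place: 4-hydroxy-2-oxopiperidin-1-yl in place of acetyl(methyl)amino on an aromatic carbon. The group that enters is the 2-oxopiperidin-1-yl ring of compound 1 carrying an additional hydroxyl, so compound 4 sits between compound 1 and compound 3 in structure, on the same core.

Among the compounds with values here, the only step that bears on this change is a 1.3-fold higher number from compound 1 to compound 3 (0.12 log units; within the scatter), which showed that swapping 2-oxopiperidin-1-yl for acetyl(methyl)amino left this assay essentially unchanged. Returning to a six-membered lactam ring that now bears a hydroxyl is therefore expected to produce no step beyond the scatter, with compound 4 expected to remain close to compound 1 and compound 3; the step of a 1.4-fold lower number from compound 3 to compound 4 (0.15 log units; within the scatter) is the expected shift. Compound 4 is estimated at 12 mL.min-1.g-1, with a range from 6 mL.min-1.g-1 to 25 mL.min-1.g-1.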

Compound 4, intrinsic clearance in microsomes: 13 mL.min-1.g-1
For compound 4 the middle estimate is 1.1-fold (0.03 log units) below the measured one; the measured number falls inside the stated range.
By their numbers in this assay, from the lowest: compounds 1, 4 and 3 (each within the scatter of the next); then compound 2.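

Hydroxy in place of hydrogen on a saturated ring carbon of the 2-oxopiperidin-1-yl group gives no change at the digits printed from compound 1 to compound 4 (within the scatter) in this assay, and this is the first change shown on the lactam ring itself rather than a swap of the whole group. Replacing acetyl(methyl)amino with 4-hydroxy-2-oxopiperidin-1-yl, which brings a hydrogen-bond donor to an aromatic carbon where the group that leaves has none, gives a 1.3-fold lower number from compound 3 to compound 4 (0.12 log units; within the scatter), so all three groups shown at this place on the shared core now lie within the scatter of one another. No measurement shown here offers an explanation for this flat read-out.

From the compounds shown here alone, it remains open whether this assay would stay as flat with an amine or a carboxylic acid on the lactam ring, or with a longer alkyl chain in place of the whole group. The compounds also leave open whether hydroxy in place of hydrogen would leave the read-out as unmoved on a different core, such as that of compound 2.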